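Two inactive-looking limits, and an isobutyl swap

This account rests on a few compounds, and the source may have more. Where it says the series, first, only, none or still open, it means among the compounds named here.

compound 1 `COc1cc(/C=C/C(=O)/C=C(/C=C/c2ccc(OC(C)=O)c(OC)c2)NC2CCCCC2)ccc1OC(C)=O` gives > 25000 nM as a limit
compound 2 `CCCNC(=C\C(=O)/C=C/c1ccc(O)c(OC)c1)/C=C/c1ccc(O)c(OC)c1` gives > 25000 nM as a limit

Both entries come from an ADME assay on EA.hy 926 cells (Homo sapiens) for inhibition, read by sulforhodamine B assay, with a stated time of 72 h (on this read-out higher numbers stand for weaker inhibition and lower numbers for stronger inhibition), and neither is a true number. Compound 1 therefore stands only at a limit, and the same mark holds for the whole small set: the limit of > 25000 nM in this assay, at which 2 of the 2 values shown sit, is all that has been seen so far. Compound 3 `COc1cc(/C=C/C(=O)/C=C(/C=C/c2ccc(OC(C)=O)c(OC)c2)NCC(C)C)ccc1OC(C)=O` has yet to be measured. It carries isobutyl in place of cyclohexyl on an amine nitrogen and keeps the rest of compound 1 unchanged. Among the measured compounds shown here, no measured step exists to guide the size of this change. For the measured compounds named here, the expected result, a step that the limit leaves unreadable from compound 1 to compound 3, is no shift beyond the scatter and no clear direction, resting only on the limit of > 25000 nM in this assay, at which 2 of the 2 values shown sit, as the sole evidence. Compound 3 is estimated at 28000 nM with an expected range of 10000 nM to 60000 nM in this assay as well.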

Compound 3, half-maximal inhibitory concentration: > 25000 nM
Compound 3: no number, only a limit (the forecaster's own chance of this, stated with the estimate: 75%); the middle value lies beyond the limit too.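

Among the compounds shown here, compound 1 and compound 3 each give only a limit, and no step between them can be read. The compounds shown leave open whether isobutyl in place of cyclohexyl changes inhibition at all, with every result resting on one mark: the limit of > 25000 nM in this assay, at which 3 of the 3 values shown sit.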